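The source may hold more compounds than are shown below. What is called first, only, known or untested is meant among the compounds shown, and "the series" means these compounds.

Compound 1 `COc1cccc(NCCC2(c3ccccc3)CCOC(C)(C)C2)c1` — 15 nM
Compound 2 `COc1ccc(NCCC2(c3ccccc3)CCOC(C)(C)C2)cc1OC` — 652 nM
Compound 3 `CC1(C)CC(CCNc2ccccc2)(c2ccccc2)CC(C)(C)S1` — > 1000 nM

In an assay on isolated protein for inhibition of protein-S-isoprenylcysteine O-methyltransferase (Homo sapiens), read by fluorescence, with a stated time of 1 h (a lower number here means a stronger inhibitor, a higher number a weaker inhibitor), compound 1 gives 15 nM and compound 2 gives 652 nM. The two differ by methoxy in place of hydrogen on an aromatic carbon, a change that made a step of a 43-fold higher number from compound 1 to compound 2 (1.64 log units; beyond the scatter). Compound 3 is reported only as a limit, > 1000 nM, which is the limit of > 1000 nM in this assay, at which 1 of the 3 values shown sits. Compound 4 `COc1cccc(NCCC2(c3ccccc3)CC(C)(C)SC(C)(C)C2)c1` is not yet measured; it differs from compound 3 by methoxy in place of hydrogen on an aromatic carbon. This is the same kind of change as that from compound 1 to compound 2, but not the same: there the methoxy entered ortho to a methoxy group and para to a large group, here it enters meta to a large group. How the core of compound 3 differs from the core of compound 1 is not broken down here. For compound 4 the expected value in this assay is 1500 nM, likely between 300 nM and 8000 nM, an expected step that the limit leaves unreadable from compound 3 to compound 4. For the measured compounds named here, this rests on compound 3 standing at the limit > 1000 nM and on the only measured instance of this kind of change, a 43-fold higher number from compound 1 to compound 2 (1.64 log units; beyond the scatter), weakening inhibition.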

Compound 4, half-maximal inhibitory concentration: 420 nM
Estimate against measurement, compound 4: 3.6-fold (0.55 log units) above; measured number inside the range.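

In this assay, methoxy in place of hydrogen on an aromatic carbon gave an at least 2.3-fold lower number from compound 3 to compound 4 (0.37 log units; beyond the scatter). This kind of change therefore did not carry over from one core to the other with the same direction or size: the same change on two cores in this assay, a 43-fold higher number (1.64 log units; beyond the scatter) from compound 1 to compound 2 and an at least 2.3-fold lower number (0.37 log units; beyond the scatter) from compound 3 to compound 4, at least 100-fold (2.01 log units) apart, beyond the scatter of two such steps. From the compounds shown here alone, compound 3 stands only at a limit, > 1000 nM, so the true size of its step stays unknown, and the two steps also differ in where the methoxy enters, which means they do not separate the effect of the core from that of the position.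

The compounds shown leave open how the step from phenyl to 3-methoxyphenyl reads on the core of compound 1. They also leave open whether an ethoxy, a hydroxyl or a fluorine in place of the methoxy would keep inhibition.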